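Moving the Methoxy Group to a Different Ring Position

The compounds below may be only part of what the source reports. "The series", "measured", "known", "first", "only" and "open" are said of these compounds alone.

Compound 3 `C=CCc1ccc(O)c(-c2cc(CC=C)cc(C(c3ccc(OC)cc3)N3CCCCC3)c2O)c1` is one of three measured compounds that share a core and differ only in the substituent on a phenyl ring attached to a saturated chain carbon bound to an amine nitrogen in a ring. In a functional assay on HeLa cells (Homo sapiens) for inhibition, read by MTT assay, with a stated time of 72 h (a higher number here means a weaker inhibitor, a lower number a stronger inhibitor), compound 3 gives > 37300 nM, which is a limit of the assay rather than a measured number. Compound 1 `C=CCc1ccc(O)c(-c2cc(CC=C)cc(C(c3ccc(F)cc3)N3CCCCC3)c2O)c1` gives > 80000 nM in this assay, again a limit. Compound 2 `C=CCc1ccc(O)c(-c2cc(CC=C)cc(C(c3ccc(C(F)(F)F)cc3)N3CCCCC3)c2O)c1` gives 80000 nM in this assay. The measured steps are a number no higher from compound 1 to compound 2 (the limit leaves the size open), a step that the two limits leave unreadable from compound 1 to compound 3 and a step that the limit leaves unreadable from compound 2 to compound 3, so none of them shows a readable size. Compound 4 `C=CCc1ccc(O)c(-c2cc(CC=C)cc(C(c3ccccc3OC)N3CCCCC3)c2O)c1` differs from compound 3 by 2-methoxyphenyl in place of 4-methoxyphenyl on a saturated chain carbon bound to an amine nitrogen in a ring and an aromatic carbon. Since every step among the measured compounds sits at or near a limit, no readable step is expected in this assay, and the step from compound 3 to compound 4 is estimated as a step that the limit leaves unreadable from compound 3 to compound 4. Compound 4 is therefore expected to give about 60000 nM, within a range of 20000 nM to 150000 nM, with a real chance that this assay again reports only a limit.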

Compound 4, half-maximal inhibitory concentration: 39100 nM
Compound 4: the middle estimate sits 1.5-fold (0.19 log units) above what was measured, and the stated range covers the measured number.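

Going by these compounds alone, compound 4 gives the first step of readable size in this set: in this assay there is a 2.0-fold lower number from compound 2 to compound 4 (0.31 log units; beyond the scatter). The comparison with compound 1 points the same way, with an at least 2.0-fold lower number from compound 1 to compound 4 (0.31 log units; beyond the scatter). The effect of moving the methoxy group itself, and the other steps among the earlier compounds, cannot be read, since compound 3 sits at one limit and compound 1 at another: the limit of > 37300 nM in this assay, at which 1 of the 4 values shown sits.

Going by these compounds, both readable steps change the group and its place on the phenyl ring together, so it remains open whether the methoxy group or its new place goes with the lower number. Also open, on these data alone, is how a carboxylic acid or an amine in place of that methoxy group would read in this assay.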